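Hydroxy to fluoro: what compound 3 may show

This account rests on a few compounds, and the source may have more. Where it says the series, first, only, none or still open, it means among the compounds named here.

In a functional assay on HCT-8 cells (Homo sapiens) for cytotoxicity (on this read-out higher numbers stand for an effect only at larger amounts of compound and lower numbers for an effect already at smaller amounts), compound 2 (`COC1=C(C)C(=O)/C(=C(O)/C=C/c2ccc(O)cc2)C(=O)C1(C)C`) gives 14.8 ug/mL and compound 1 (`COC1=C(C)C(=O)/C(=C(O)/C=C/c2ccc(Br)cc2)C(=O)C1(C)C`) gives 7.4 ug/mL, so the two cannot be told apart beyond the usual scatter. Compound 3 (`COC1=C(C)C(=O)/C(=C(O)/C=C/c2ccc(F)cc2)C(=O)C1(C)C`) has not been measured yet. It keeps the shared core of compound 2 and differs from it in one place: fluoro in place of hydroxy on an aromatic carbon. Put simply, 4-hydroxyphenyl becomes 4-fluorophenyl, with fluoro in place of hydroxy on an aromatic carbon. Within the data shown here, one measured step bears on this, an exchange of bromo for hydroxy on that carbon, and it is small: a 2.0-fold higher number from compound 1 to compound 2 (0.30 log units; within the scatter). With only a 2.0-fold higher number from compound 1 to compound 2 (0.30 log units; within the scatter) to go on, no step beyond the scatter is expected in this assay. The estimate amounts to a 1.5-fold lower number from compound 2 to compound 3 (0.17 log units; within the scatter), which is expected to stay within the scatter. For compound 3 the expected value is 10 ug/mL, with an estimated range of 4 ug/mL to 25 ug/mL.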

Compound 3, concentration for half-maximal effect: 3.6 ug/mL
Estimate against measurement, compound 3: 2.8-fold (0.44 log units) above; measured number outside the range, below it.
By their numbers in this assay, from the lowest: compound 3; then compounds 1 and 2 (each within the scatter of the next).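

Until now, the group on this aromatic carbon had made no difference beyond the scatter, but in this assay there is a 4.1-fold lower number from compound 2 to compound 3 (0.61 log units; beyond the scatter), so the choice of group here can shift the number. The exchange of bromo for fluoro also counts, with a 2.1-fold lower number from compound 1 to compound 3 (0.31 log units; beyond the scatter), which shows that these two halogens are not interchangeable at this carbon, although both steps are modest. Compound 3, with fluoro, therefore has the lowest number of the three, and its steps to both other compounds lie beyond the scatter.

Nothing shown gives a measured reason for these differences. Going by these compounds, it also remains open whether chloro, methoxy or an amine on the same carbon would give a number near that of compound 3 or nearer those of the other two compounds.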